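A Bromophenyl Swap on a Shared Anti-Inflammatory Core

The source may report more compounds than this note shows. Statements on the series, on what has been measured and on what is new or still open speak of the compounds shown alone.

Measured so far:
Compound 1, `CC(=O)Oc1ccc(-n2c(-c3ccccc3)cc3c2CCCC3)cc1C(=O)O`: 50%
Compound 2, `COc1ccccc1-c1cc2c(n1-c1ccc(O)c(C(=O)O)c1)CCCC2`: 50%

Both compounds were tested in a functional assay on the whole organism (strain Wistar) for inhibition, with Rattus norvegicus as the target, read by paw edema, with stated times of 30 min and 3 h, at a dose of 200 mg/kg by the oral route; on this read-out lower numbers stand for less inhibition and higher numbers for more inhibition at the one dose given (going by the name of the read-out). In this assay compound 1 gives 50%, and compound 2 gives 50%. The two values are level at the digits shown, and compound 2 sits within the usual scatter of compound 1, so the numbers alone do not separate them. Within the data shown here, no single-point step between measured compounds is available, so there is no measured guide to how one change on this core moves the read-out.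

Compound 3, `O=C(O)c1cc(-n2c(-c3ccc(Br)cc3)cc3c2CCCC3)ccc1O`, is the next compound to be tested in this assay. It differs from compound 2 in one place: 4-bromophenyl in place of 2-methoxyphenyl on an aromatic carbon. With nothing else to go on, the fairest expectation is that compound 3 stays where compound 2 stands, within the scatter of the assay. The step of no change at the digits printed from compound 2 to compound 3 (within the scatter) is expected to be no larger than that scatter. Compound 3 is therefore estimated to give 50% in this assay, with a range from 35% to 65%.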

Compound 3, a percentage reported as inhibition, in the whole organism at one dose (the size of the read-out at that dose, not a potency): 40%
For compound 3 the middle estimate is 10 percentage points above the measured one; low and high end bracket the measured number.
By their numbers in this assay, from the lowest: compounds 3, 1 and 2 (each within the scatter of the next).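

In this assay, putting 4-bromophenyl in place of 2-methoxyphenyl on the aromatic carbon next to the ring nitrogen gives a number 10 percentage points lower from compound 2 to compound 3 (within the scatter). Among these compounds, this is the first single-place comparison on the shared core, and it shows that this position accepts two quite different aryl groups with no change that can be told from the scatter, even though the entering group has a bromine where the leaving group has an oxygen and one hydrogen-bond acceptor fewer. No measured information on these compounds explains this outcome.

The compounds shown leave open whether a group of another kind at this place, such as an amine, a carboxylic acid or a longer alkyl chain in place of the aryl ring, would move the read-out beyond the scatter. The read-out also gives the size of the effect at one oral dose rather than a potency, so how these compounds would compare across a range of doses remains an open question.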